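Swapping the anilino substituent on a pyrimidine series

This account rests on a few compounds, and the source may have more. Where it says the series, first, only, none or still open, it means among the compounds named here.

Of the compounds shown here, three sharing one core have been measured in a functional assay on B16-F10 cells (Mus musculus) for inhibition, read by MTT assay, with a stated time of 72 h; on this read-out higher numbers stand for weaker inhibition and lower numbers for stronger inhibition. Compound 1 `CC(C)c1ccc(-c2nc(SCc3cn(CC(=O)NC(=O)Nc4ccccn4)nn3)nc(Nc3ccc(Cl)cc3)c2C#N)cc1` gives 860 nM. Compound 2 `CC(C)c1ccc(-c2nc(SCc3cn(CC(=O)NC(=O)Nc4ccccn4)nn3)nc(Nc3cccc([N+](=O)[O-])c3)c2C#N)cc1`, which carries a 3-nitrophenyl on the ring nitrogen instead of the 4-chlorophenyl, gives 26400 nM, a step of a 31-fold higher number from compound 1 to compound 2 (1.49 log units; beyond the scatter). Compound 3 `COc1ccc(Nc2nc(SCc3cn(CC(=O)NC(=O)Nc4ccccn4)nn3)nc(-c3ccc(C(C)C)cc3)c2C#N)cc1` gives 360 nM, the lowest of the three numbers; the move from the chloro to the methoxy group is a 2.4-fold lower number from compound 1 to compound 3 (0.38 log units; beyond the scatter), and the move from compound 2 is a 73-fold lower number from compound 2 to compound 3 (1.87 log units; beyond the scatter).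

Compound 4 `Cc1cccc(Nc2nc(SCc3cn(CC(=O)NC(=O)Nc4ccccn4)nn3)nc(-c3ccc(C(C)C)cc3)c2C#N)c1` has not yet been measured. Its difference from compound 3 is 3-methylphenyl in place of 4-methoxyphenyl on a nitrogen on an aromatic ring. Among the compounds with values here, no measured step repeats this exact exchange. The nearest guides are the modest step from compound 1 to compound 3, where one group on the phenyl was traded for another, and the large step from compound 2 to compound 3, where both the group and its position changed. Because compound 3 gives 360 nM and the 4-chlorophenyl analogue compound 1 gives 860 nM, a small-to-modest weakening is expected when the methoxy-bearing ring is replaced by the methyl-bearing one, not a swing of the size seen with the nitro compound. The expected step is a 2.8-fold higher number from compound 3 to compound 4 (0.44 log units; beyond the scatter). Compound 4 is therefore estimated at 1000 nM, with a likely range from 300 nM to 4000 nM.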

Compound 4, half-maximal inhibitory concentration: 1650 nM
For compound 4 the middle estimate is 1.7-fold (0.22 log units) below the measured one, and the stated range covers the measured number.
By their numbers in this assay, from the lowest: compound 3; then compounds 1 and 4 (each within the scatter of the next); then compound 2.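

In this assay, replacing 4-methoxyphenyl, with its one hydrogen-bond acceptor, by 3-methylphenyl, with none, gives a 4.6-fold higher number from compound 3 to compound 4 (0.66 log units; beyond the scatter), and this leaves compound 3 with the lowest number of the four. Compound 2 and compound 4 carry 3-nitrophenyl and 3-methylphenyl, and methyl in place of nitro gives a 16-fold lower number from compound 2 to compound 4 (1.20 log units; beyond the scatter), which shows that the high number of compound 2 goes with the nitro group and not with the ring pattern that these two compounds share. The exchange of 4-chlorophenyl for 3-methylphenyl gives a 1.9-fold higher number from compound 1 to compound 4 (0.28 log units; within the scatter), so these two groups cannot be told apart on this read-out.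

The compounds shown leave open how much of the gap between compound 3 and compound 4 belongs to the group and how much to its place on the ring, which 4-methylphenyl or 3-methoxyphenyl would help to separate, and how an amine or a carboxylic acid on the same ring would read. No supporting data are available to explain any of these steps.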